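Mirror-image linker in a glutamate receptor modulator series

A few compounds are considered here, and "the series" means these few. Any claim that something is new, unique, unknown or untested is made for them only; others in the source may bear on it.

Three compounds share a core and a chiral propylene-oxy linker. In an assay for positive allosteric modulation of metabotropic glutamate receptor 2 (Rattus norvegicus) (on this read-out lower numbers stand for an effect already at smaller amounts and higher numbers for an effect only at larger amounts of compound), compound 1 `Cc1c(OC[C@@H](C)Oc2ccc(F)c(C(=O)O)c2)ccc(C(=O)CC(C)(C)C)c1O` gives 112 nM, compound 2 `COc1ccc(C(=O)O)cc1O[C@@H](C)COc1ccc(C(=O)CC(C)(C)C)c(O)c1C` gives 137 nM, and compound 3 `Cc1c(O[C@@H](C)COc2ccc(F)c(C(=O)O)c2)ccc(C(=O)CC(C)(C)C)c1O` gives 257 nM. Compound 3 thus has the highest number of the three; its gap to compound 2 stays within the usual scatter, while its gap to compound 1 lies beyond it. Compound 4 `Cc1c(O[C@H](C)COc2ccc(F)c(C(=O)O)c2)ccc(C(=O)CC(C)(C)C)c1O` is not yet measured. Compared with compound 3, (the two compounds have the same atoms and bonds and differ only in configuration as drawn: 1 of 1 stereo elements differ; a stereocentre at a saturated chain carbon is drawn S in compound 3 and R in compound 4). Going by the values given here, no pair of measured compounds here differs only in configuration, so the size and direction of such a step cannot be read from the data. Because compound 3 gives 257 nM, compound 4 is expected to land at 350 nM, within a broad span from 80 nM to 2000 nM, with an estimated step of a 1.4-fold higher number from compound 3 to compound 4 (0.13 log units; within the scatter) in this assay.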

Compound 4, half-maximal effective concentration: 83 nM
Beside the measured number, compound 4's estimate is 4.2-fold (0.62 log units) above it; low and high end bracket the measured number.
By their numbers in this assay, from the lowest: compounds 4, 1, 2 and 3 (each within the scatter of the next, the first and the last beyond it).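

Changing the saturated chain carbon from S to R gives a 3.1-fold lower number from compound 3 to compound 4 (0.49 log units; beyond the scatter) in this assay, a modest step, and the first view of what configuration alone does in this series. The step can be assigned to this stereocentre alone because nothing else changes: the fact that compounds 3 and 4 differ only in the configuration as drawn

Why the R form gives the lower number remains open. So does whether a similar step would appear with an ethyl group in place of the methyl group on this stereocentre, or on inverting the stereocentre of compound 2.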